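Compound 4: Hydrogen in Place of Methoxy

The source may report more compounds than this note shows. Statements on the series, on what has been measured and on what is new or still open speak of the compounds shown alone.

In a functional assay on MKN-45 cells (Homo sapiens) for antiproliferative activity, read by MTT assay, with a stated time of 72 h (on this read-out higher numbers stand for weaker inhibition and lower numbers for stronger inhibition), compound 2 `COCCOc1cc2nccc(Oc3ccc(Nc4nccc5[nH]cc(-c6ccc(F)cc6)c(=O)c45)cc3F)c2cc1OC` gives 3100 nM. This lies within the scatter of both other measured compounds: compound 1 `COc1cc2c(Oc3ccc(Nc4nccc5[nH]cc(-c6ccc(F)cc6)c(=O)c45)cc3F)ccnc2cc1OCCO` gives 1600 nM, and compound 3 `CC(C)(O)COc1ccc2c(Oc3ccc(Nc4nccc5[nH]cc(-c6ccccc6)c(=O)c45)cc3F)ccnc2c1` gives 2900 nM. The next structure, compound 4 `COCCOc1ccc2c(Oc3ccc(Nc4nccc5[nH]cc(-c6ccc(F)cc6)c(=O)c45)cc3F)ccnc2c1`, comes from compound 2 by one change, hydrogen in place of methoxy on an aromatic carbon.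

Among the compounds with values here, no measured step tests this change directly. Within the data shown here, the one single-place step, a 1.9-fold higher number from compound 1 to compound 2 (0.29 log units; within the scatter), concerns methyl in place of hydrogen on an oxygen, elsewhere in the molecule, and stays within the scatter. Compound 3 also carries no methoxy on that ring and gives 2900 nM, but it differs from compound 4 in other places too, so it offers only loose support. On these data alone, no step beyond the scatter is therefore expected in this assay, and the direction remains open. The estimate amounts to a 1.1-fold lower number from compound 2 to compound 4 (0.04 log units; within the scatter), an expected step within the scatter. For compound 4 the expected value is 2800 nM, with an estimated range from 1200 nM to 6500 nM.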

Compound 4, half-maximal inhibitory concentration: 5600 nM
Compound 4: middle estimate off by 2.0-fold (0.30 log units), on the low side; measured number inside the range.
By their numbers in this assay, from the lowest: compounds 1, 3, 2 and 4 (each within the scatter of the next, the first and the last beyond it).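

Within the data shown here, the first direct reading at this aromatic carbon comes from putting hydrogen in place of methoxy, which in this assay gives a 1.8-fold higher number from compound 2 to compound 4 (0.26 log units; within the scatter). Among these compounds, the methoxy group, ortho to the 2-methoxyethoxy group, can therefore be absent from this pair without a step beyond the scatter, although this is only one pair and a single change. Nothing available bears on the cause of this result.

The compounds shown leave open whether another group on this carbon, such as an amine, a carboxylic acid or a longer alkoxy chain, would give a step beyond the scatter. They also leave open whether the same change would read alike with the chain of compound 1 in place of the 2-methoxyethoxy group.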